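Swapping pyridin-2-yl for pyridin-4-yl in compound 3

The source may hold more compounds than are shown below. What is called first, only, known or untested is meant among the compounds shown, and "the series" means these compounds.

Three related compounds have been tested so far in a functional assay on MCF7 cells (Homo sapiens) for cytotoxicity, read by sulforhodamine B assay, with a stated time of 48 h; a lower number here means a stronger inhibitor, a higher number a weaker inhibitor. Compound 1 `N#Cc1cc(-c2ccccc2)n(-c2nc3ccccc3[nH]2)c1N` gives 1280 nM, and compound 2 `N#Cc1cc(-c2ccccc2)n(Cc2nc3ccccc3[nH]2)c1N` gives 515 nM. Compound 3 `Nc1c(-c2nc3ccccc3[nH]2)cc(-c2ccccc2)n1-c1ccccn1` gives 934 nM. That number falls inside the range of the other two, and its gaps to both lie within the usual scatter of repeated measurements, so compound 3 cannot be told apart from either of them.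

Compound 4 `Nc1c(-c2nc3ccccc3[nH]2)cc(-c2ccccc2)n1-c1ccncc1` has not been measured yet. It holds the same atoms as compound 3, joined differently: pyridin-4-yl in place of pyridin-2-yl on an aromatic nitrogen. The rest of the molecule stays the same.

Among the measured compounds shown here, no measured pair in this small set shows a change of this kind, so any forecast is uncertain. With values running only from compound 2 at 515 nM to compound 1 at 1280 nM, no change beyond the scatter is expected in this assay. The estimated shift is small: a 1.2-fold lower number from compound 3 to compound 4 (0.07 log units; within the scatter). For compound 4 the expected value is 800 nM, with an estimated range of 350 nM to 1900 nM.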

Compound 4, half-maximal inhibitory concentration: 705 nM
Beside the measured number, compound 4's estimate is 1.1-fold (0.05 log units) above it; the range from low to high includes it.
By their numbers in this assay, from the lowest: compounds 2, 4, 3 and 1 (each within the scatter of the next, the first and the last beyond it).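

Among the compounds shown here, exchanging pyridin-2-yl for pyridin-4-yl on the aromatic nitrogen gives a 1.3-fold lower number from compound 3 to compound 4 (0.12 log units; within the scatter) in this assay and provides the first step in this set between two compounds that differ in only one place. At this position, the two attachments of the same six-membered aromatic ring cannot be told apart, so moving the ring nitrogen within this group, while the heavy atoms and the counted hydrogen-bond donors and acceptors stay the same, leaves compound 3 and compound 4 within the scatter of each other. No separate measurement bears on this result, so the data offer no explanation for it.

For the compounds shown here, this single step covers only two attachments of one ring, so pyridin-3-yl remains the obvious missing member of the series, and a plain phenyl would show whether a ring nitrogen in this group matters at all. Further along, a saturated piperidine ring or a short chain such as methyl or ethyl on the same aromatic nitrogen would show whether any group very different from these two gives a step beyond the scatter.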